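Swapping fluoro for bromo on a stilbene-like diaryl ethane

This account rests on a few compounds, and the source may have more. Where it says the series, first, only, none or still open, it means among the compounds named here.

Compound 1 `COc1cc(CCc2ccc(F)cc2)cc(OC)c1O`: 5470 nM
Compound 2 `COc1cc(CCc2cccc(Cl)c2Cl)cc(OC)c1O`: 4770 nM

Of the compounds shown here, two share a core and have been tested in a functional assay on HepG2 cells (Homo sapiens) for antiproliferative activity, read by MTT assay, with a stated time of 72 h; a higher number here means a weaker inhibitor, a lower number a stronger inhibitor. Compound 1 gives the highest of the two numbers, but compound 2 sits so close that the two values show no difference beyond the scatter. Compound 3 `COc1cc(CCc2ccc(Br)cc2)cc(OC)c1O` has not yet been measured. It differs from compound 1 only in one place: bromo in place of fluoro on an aromatic carbon. Going by the values given here, with no step between measured compounds to lean on, the expectation for this change in this assay is a small one, probably within the scatter, and if anything toward a slightly lower number. The step from compound 1 to compound 3 is thus estimated as a 1.4-fold lower number from compound 1 to compound 3 (0.14 log units; within the scatter). Compound 3 is expected to give about 4000 nM, with a likely range from 1500 nM to 11000 nM.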

Compound 3, half-maximal inhibitory concentration: 8490 nM
The estimate for compound 3 lay 2.1-fold (0.33 log units) below the measured number; measured number inside the range.
By their numbers in this assay, from the lowest: compounds 2, 1 and 3 (each within the scatter of the next).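

Read in this assay, the first step at this position, bromo in place of fluoro on an aromatic carbon para to a large group, comes out as a 1.6-fold higher number from compound 1 to compound 3 (0.19 log units; within the scatter) and so stays small. At this carbon the two halogens therefore cannot be told apart: one can stand in for the other without a difference that repeat measurements could separate from ordinary noise, and bromo brings no clear gain. Nothing measured here offers an explanation for the step.

Going by these compounds, it remains open whether this carbon tolerates groups other than halogens, such as an amine, a carboxylic acid or a nitrile, any of which might move the number well beyond the scatter. A single step also cannot show how the same swap would read elsewhere on the shared core.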